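Following the step from compound 2 to compound 4

The compounds below may be only part of what the source reports. "The series", "measured", "known", "first", "only" and "open" are said of these compounds alone.

Measured in a functional assay on the whole organism (stomach) with Rattus norvegicus as the target; a lower number here means that less compound is needed, a higher number that more compound is needed for the effect:
- compound 2, `C/N=C(\S)NCCCCCn1nc(-c2ccccc2)ccc1=O`, gives 35.3 mg/kg
- compound 3, `N/C(S)=N/CCCCn1nc(-c2ccccc2)ccc1=O`, gives 36.3 mg/kg
- compound 1, `C/N=C(/NC#N)NCCCn1nc(-c2ccccc2)ccc1=O`, gives only a limit, > 100 mg/kg

Compound 2 holds the lowest of the two numbers in this assay, with compound 3 within the scatter of it, as the step of a 1.0-fold higher number from compound 2 to compound 3 (0.01 log units; within the scatter) shows. The value of compound 1 is a limit and not a number (the limit of > 100 mg/kg in this assay, at which 1 of the 3 values shown sits).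

Compound 4, `CN(C)/C(=N/CCCCCCn1nc(-c2ccccc2)ccc1=O)NC#N`, differs from compound 2 in one place: a group of 9 heavy atoms (5 carbon, 4 nitrogen; no ring) in place of a group of 5 heavy atoms (2 carbon, 2 nitrogen, 1 sulfur; no ring), on a saturated chain carbon, five bonds along the chain from an aromatic nitrogen. The group that leaves is the one that, in the steps of an at least 2.8-fold lower number from compound 1 to compound 2 (0.45 log units; beyond the scatter) and an at least 2.7-fold lower number from compound 1 to compound 3 (0.44 log units; beyond the scatter), brought the number down from the limit of compound 1 to the numbers of compounds 2 and 3; the group that enters carries the nitrile and two nitrogens that the group of compound 1 also carried, though with two more carbons and on a longer chain. Those two steps therefore bear on the move to compound 4, and they point toward a higher number, of at least modest size, with a fair chance that the assay again reports only a limit.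

The number expected for compound 4 is 100 mg/kg, within 35 mg/kg to 300 mg/kg. This estimate for compound 4 means a step of a 2.8-fold higher number from compound 2 to compound 4 (0.45 log units; beyond the scatter).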

Compound 4, dose for half-maximal effect: 93.1 mg/kg
Estimate against measurement, compound 4: 1.1-fold (0.03 log units) above; measured number inside the range.
By their numbers in this assay, from the lowest: compounds 2 and 3 (each within the scatter of the next); then compound 4. At a limit, above all of these: compound 1.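

In this assay, the exchange at this place, on a saturated chain carbon five bonds along the chain from an aromatic nitrogen, gives a measured step: a 2.6-fold higher number from compound 2 to compound 4 (0.42 log units; beyond the scatter). Within the data shown here, compound 4 thus gives the first actual number for a group carrying a nitrile, and it places this group on the higher side of the sulfur-bearing groups of compound 2 and compound 3, whose own values lie within the scatter of each other. For compound 1, the other compound with a nitrile, the result is still a limit and not a number: the limit of > 100 mg/kg in this assay, at which 1 of the 4 values shown sits.

The step from compound 2 changes the whole group at once, so the compounds shown do not tell how much of it belongs to the nitrile, to the loss of the sulfur or to the added carbons. From the compounds shown here alone, it also remains open whether a urea, with oxygen in place of the sulfur, an amine or a longer chain at this place would give a number nearer to that of compound 2 or to that of compound 4.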